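This account rests on a few compounds, and the source may have more. Where it says the series, first, only, none or still open, it means among the compounds named here.

Three compounds share one core. In a functional assay on HL-60 cells (Homo sapiens) for cytotoxicity, read by MTT assay, with a stated time of 48 h (on this read-out higher numbers stand for weaker inhibition and lower numbers for stronger inhibition), compound 1 `COc1ccc(Nc2nc(-c3cccc(F)c3)nc3ccc(F)cc23)cc1` gives 38600 nM as a real number. Compound 2 `COc1ccccc1Nc1nc(-c2cccc(F)c2)nc2ccc(F)cc12` in this assay stops at the limit > 50000 nM and gives no number. Compound 3 `Fc1cccc(-c2nc(Nc3ccccc3Cl)c3cc(F)ccc3n2)c1` in this assay likewise stops at the limit > 50000 nM and gives no number. Compound 3 thus stands where most of the values sit (the limit of > 50000 nM in this assay, at which 2 of the 3 values shown sit), with nothing readable behind it. The step of an at least 1.2-fold higher number from compound 1 to compound 3 (0.11 log units; that floor lies within the scatter) is small, and a step that the two limits leave unreadable from compound 2 to compound 3 cannot be sized. The unmeasured compound 4 `Nc1ccccc1Nc1nc(-c2cccc(F)c2)nc2ccc(F)cc12` differs from compound 3 by amino in place of chloro on an aromatic carbon. Among the compounds with values here, no measured step swaps chloro for amino, so nothing here points to a gain; the expected step of a number no higher from compound 3 to compound 4 (the limit leaves the size open) is none beyond the scatter. Compound 4 is therefore estimated at 50000 nM, within 20000 nM to 150000 nM.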

Compound 4, half-maximal inhibitory concentration: 41300 nM
The estimate for compound 4 lay 1.2-fold (0.08 log units) above the measured number; low and high end bracket the measured number.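

With amino on this aromatic carbon, ortho to a large group, compound 4 gives a real number in this assay, where chloro in compound 3 and methoxy in compound 2 stop at a limit. Even so, the readable floors are small: an at least 1.2-fold lower number from compound 3 to compound 4 (0.08 log units; that floor lies within the scatter) and an at least 1.2-fold lower number from compound 2 to compound 4 (0.08 log units; that floor lies within the scatter). Within the data shown here, the comparison with the only other real number is a 1.1-fold higher number from compound 1 to compound 4 (0.03 log units; within the scatter), so this swap shows no gain beyond the scatter. Going by these compounds, how large the first two steps truly are stays open because two compounds stop at a limit: the limit of > 50000 nM in this assay, at which 2 of the 4 values shown sit. Whether a hydroxyl or dimethylamino group on this carbon would give a step beyond the scatter also stays open.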